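Propanoyl Capping of a Hydroxymethyl Group in Rat Paw Edema

The source may hold more compounds than are shown below. What is called first, only, known or untested is meant among the compounds shown, and "the series" means these compounds.

Measured so far:
Compound 1, `CCC(=O)NS(=O)(=O)c1ccc(-n2nc(C(F)(F)F)cc2-c2ccc(Br)cc2)cc1COC(=O)CC`: 12.5 mg/kg
Compound 2, `CCC(=O)NS(=O)(=O)c1ccc(-n2nc(C(F)(F)F)cc2-c2ccc(Br)cc2)cc1CO`: 7.2 mg/kg
Compound 3, `NS(=O)(=O)c1ccc(-n2nc(C(F)(F)F)cc2-c2ccc3c(c2)CCO3)cc1CO`: 22.3 mg/kg

All three compounds were tested in a functional assay on the whole organism (strain Wistar) with Rattus norvegicus as the target, read by paw edema; a higher number here means that more compound is needed for the effect, a lower number that less compound is needed. Compound 2 and compound 1 share one core and differ in a single place: propanoyl in place of hydrogen on an oxygen on a saturated carbon. That change gave a 1.7-fold higher number from compound 2 to compound 1 (0.24 log units; within the scatter), so the two values cannot be told apart with confidence.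

Compound 3 carries a different core, and how it differs from compound 2 is not broken down here; what the values show is that compound 3 needs a higher dose than compound 2, a gap that lies beyond the scatter, while compound 3 and compound 1 sit within the scatter of each other.

Compound 4, `CCC(=O)OCc1cc(-n2nc(C(F)(F)F)cc2-c2ccc3c(c2)CCO3)ccc1S(N)(=O)=O`, has not yet been measured. It stands to compound 3 as compound 1 stands to compound 2: propanoyl in place of hydrogen on an oxygen on a saturated carbon. The surroundings of the changed place are the same in both pairs, so this is the same change made on the other core.

Among the compounds with values here, for compound 4 the expected step is a 1.4-fold higher number from compound 3 to compound 4 (0.16 log units; within the scatter), resting on the single earlier example a 1.7-fold higher number from compound 2 to compound 1 (0.24 log units; within the scatter), which was small, together with the starting value of compound 3, 22.3 mg/kg. The estimate for compound 4 in this assay is 32 mg/kg, expected to fall between 15 mg/kg and 70 mg/kg.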

Compound 4, dose for half-maximal effect: 8.5 mg/kg
Compound 4: the middle estimate sits 3.8-fold (0.58 log units) above what was measured, and the stated range ends above it.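

In this assay, capping the hydroxymethyl group with propanoyl gave a 2.6-fold lower number from compound 3 to compound 4 (0.42 log units; beyond the scatter), so on this core the capped compound needs a clearly lower dose than its parent with the free hydroxy group. Set beside the earlier pair, the same change does not carry over from one core to the other with the same outcome, since one step stays within the scatter and the other goes beyond it in the lower direction: the same change on two cores in this assay, a 1.7-fold higher number (0.24 log units; within the scatter) from compound 2 to compound 1 and a 2.6-fold lower number (0.42 log units; beyond the scatter) from compound 3 to compound 4, 4.6-fold (0.66 log units) apart, beyond the scatter of two such steps This shows that, in this series, a result for the propanoyl cap on one core cannot simply be transferred to another, but with only two pairs, and with cores that differ in more than one place, it does not show which difference between the cores matters or why the outcome changes.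

The compounds shown leave open whether a different ester on the same oxygen, such as an acetyl group or a longer chain like butanoyl, would follow the pattern of compound 4 or that of compound 1. They also leave open how a methyl ether or a carboxylic acid in place of the hydroxymethyl group would behave on either core.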